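Removing the Phenyl from Compound 2: An Expected Step

This account rests on a few compounds, and the source may have more. Where it says the series, first, only, none or still open, it means among the compounds named here.

Of the compounds shown here, three built on a shared core have been measured in a functional assay on UO-31 cells (Homo sapiens) for antiproliferative activity, read by sulforhodamine B assay, with a stated time of 72 h; a lower number here means a stronger inhibitor, a higher number a weaker inhibitor. Compound 1 `Clc1ccc(C(/C=C/c2ccccc2)=N\Nc2nncc3ccccc23)cc1` gives 6.2 nM, compound 3 `COc1ccc(NC(=S)NNc2nncc3ccccc23)cc1` gives 47 nM, and compound 2 `O=C1CS/C(=N/Nc2nncc3ccccc23)N1c1ccccc1` gives 63 nM. Among these three, compound 2 stands at the highest number; its gap to compound 3 lies within the scatter of this assay, so the two cannot be ordered, while its gap to compound 1 lies beyond the scatter, with compound 1 at the lower number.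

Compound 4 `O=C1CS/C(=N/Nc2nncc3ccccc23)N1` is not yet measured. It differs from compound 2 in one place: hydrogen in place of phenyl on an amide-type nitrogen in a ring. Going by the values given here, no step between measured compounds shows what this change does on its own, so its effect is not known from the data. The loss of the phenyl is expected to move the number in this assay upward by a moderate step, beyond the scatter, giving a 2.5-fold higher number from compound 2 to compound 4 (0.40 log units; beyond the scatter). Compound 4 is therefore estimated at 160 nM, with a range from 50 nM to 500 nM.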

Compound 4, half-maximal inhibitory concentration: 25 nM
The estimate for compound 4 lay 6.4-fold (0.81 log units) above the measured number; measured number outside the range, below it.
By their numbers in this assay, from the lowest: compound 1; then compounds 4, 3 and 2 (each within the scatter of the next, the first and the last beyond it).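

In this assay, the phenyl on the amide-type nitrogen of the five-membered ring proves dispensable, as hydrogen in its place gives a 2.5-fold lower number from compound 2 to compound 4 (0.40 log units; beyond the scatter) and this modest step lies beyond the scatter. Going by these compounds alone, this is the first reading of a single change on the shared core, since no two earlier compounds differed in only one place. Nothing available explains the direction of this step.

The compounds shown leave open whether a methyl, or a longer chain such as propyl, on this nitrogen would give a number closer to that of compound 4 or to that of compound 2. They also leave open whether a benzyl or a methoxy-bearing phenyl at this place would differ from the unsubstituted phenyl.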